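Quinoline selenide and thioether series: antiproliferative working notes

The compounds below may be only part of what the source reports. "The series", "measured", "known", "first", "only" and "open" are said of these compounds alone.

Measured so far:
compound 1, `CSc1cnc2ccccc2c1[Se]CC#CCOC(=O)c1ccc(C(=O)O)cc1`, 3.2 ug/mL
compound 2, `ClCC#CCSc1cnc2ccccc2c1Cl`, 3.2 ug/mL

Both numbers come from a functional assay on T47D cells (Homo sapiens) for antiproliferative activity, with a stated time of 72 h; a lower number here means a stronger inhibitor, a higher number a weaker inhibitor. Compound 1 gives 3.2 ug/mL, and compound 2 gives 3.2 ug/mL; the two values are level at the digits shown and lie within the usual scatter of this kind of measurement, so no order between them can be stated. Within the data shown here, the two structures differ in several places at once, so no single step connects them, and nothing is taken from their comparison beyond the fact that the values match.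

Compound 3, `CSc1cnc2ccccc2c1[Se]CC#CCOC(=O)c1ccccc1`, has not been measured. It differs from compound 1 in one place: hydrogen in place of carboxy on an aromatic carbon. Cut one bond further out, the same difference reads 4-carboxyphenyl to phenyl. Among the measured compounds shown here, no measured pair in this set differs only here, so the effect of the change is unknown from the data. The expectation is a step of no size beyond the scatter, and it is estimated as no change at the digits printed from compound 1 to compound 3 (within the scatter). Compound 3 is therefore expected to give 3.2 ug/mL in this assay, with an estimated range from 1.3 ug/mL to 8 ug/mL.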

Compound 3, concentration for 50% inhibition: 2.2 ug/mL
Estimate against measurement, compound 3: 1.5-fold (0.16 log units) above, and the stated range covers the measured number.
By their numbers in this assay, from the lowest: compounds 3, 1 and 2 (each within the scatter of the next).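

Among these compounds, replacing carboxy with hydrogen on the aromatic carbon para to a large group, the change from 4-carboxyphenyl to phenyl, gives in this assay a 1.5-fold lower number from compound 1 to compound 3 (0.16 log units; within the scatter) and provides the first single-place step. In this pair, the carboxy group, with its 3 heavy atoms, its hydrogen-bond donor and its hydrogen-bond acceptor, can leave this position without taking the read-out beyond the scatter, which the level values of the two structurally distant earlier compounds could not show. No measured information is available to explain this outcome.

The compounds shown leave open whether another group at this position, such as an amine, a hydroxyl or a methyl ester, would take the number beyond the scatter, and whether a carboxylic acid elsewhere on the same ring would behave as it does here. They also leave open how a sulfur link compares with the selenium link when the rest of compound 3 is held fixed, and what a longer chain would do in place of the one that carries the ester.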